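Benzyl-triazole ethers of the shared core against breast cancer cells

The source may report more compounds than this note shows. Statements on the series, on what has been measured and on what is new or still open speak of the compounds shown alone.

compound 1 `O=c1ccoc2cc(OCc3cn(Cc4ccccc4Br)nn3)ccc12`: > 100000 nM
compound 2 `O=c1ccoc2cc(OCc3cn(Cc4cccc([N+](=O)[O-])c4)nn3)ccc12`: > 100000 nM

In a functional assay on MDA-MB-231 cells (Homo sapiens) for cytotoxicity, read by MTT assay, with a stated time of 48 h (a higher number here means a weaker inhibitor, a lower number a stronger inhibitor), compound 1 gives only a limit, > 100000 nM. Compound 2 likewise gives only a limit, > 100000 nM. The step that the two limits leave unreadable from compound 1 to compound 2 is therefore unreadable. Compound 3 `O=c1ccoc2cc(OCc3cn(Cc4ccccc4F)nn3)ccc12` differs from compound 2 in 2-fluorophenyl in place of 3-nitrophenyl on a saturated chain carbon bound to an aromatic nitrogen. Going by the values given here, no measured step bears on this change, and both values shown so far sit at the limit of > 100000 nM in this assay, at which 2 of the 2 values shown sit. Compound 3 is therefore expected to give 150000 nM, within 50000 nM to 500000 nM. The expected step that the limit leaves unreadable from compound 2 to compound 3 most likely remains hidden behind the limit of this assay.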

Compound 3, half-maximal inhibitory concentration: 29800 nM
Estimate against measurement, compound 3: 5.0-fold (0.70 log units) above, outside the stated range (below it).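

On the saturated chain carbon bound to an aromatic nitrogen, 2-fluorophenyl is the first group shown to come off the limit in this assay, where the other two compounds give only limits: the limit of > 100000 nM in this assay, at which 2 of the 3 values shown sit. The change from 3-nitrophenyl to 2-fluorophenyl gives an at least 3.3-fold lower number from compound 2 to compound 3 (0.52 log units; beyond the scatter), and fluoro in place of bromo on an aromatic carbon gives an at least 3.3-fold lower number from compound 1 to compound 3 (0.52 log units; beyond the scatter). Between compound 1 and compound 2 the step cannot be read, and the full size of both new steps stays open. On these data alone, what an amine, a carboxylic acid or a longer chain would give at this place also remains open.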